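Acetyl to tert-butoxycarbonyl on the piperazine amide, dithiocarbamate series

The source may report more compounds than this note shows. Statements on the series, on what has been measured and on what is new or still open speak of the compounds shown alone.

Compound 1 `COc1ccc(CN(C(=O)CSC(=S)N2CCN(C(C)=O)CC2)c2cc(OC)c(OC)c(OC)c2)cc1` gives 370 nM in a functional assay on KYSE-450 cells (Homo sapiens) for inhibition, read by CCK-8 assay, with a stated time of 48 h; a higher number here means a weaker inhibitor, a lower number a stronger inhibitor. Compound 2 `COc1ccc(CN(C(=O)CSC(=S)N2CCN(C(=O)OC(C)(C)C)CC2)c2cc(OC)c(OC)c(OC)c2)cc1` carries the change tert-butoxy in place of methyl on a carbonyl carbon and gives 250 nM in this assay; the step is a 1.5-fold lower number from compound 1 to compound 2 (0.17 log units; within the scatter). Compound 3 `COc1ccc(CN(C(=O)CN2CCN(C(C)=O)CC2)c2cc(OC)c(OC)c(OC)c2)cc1` differs from compound 1 by a group of 9 heavy atoms (6 carbon, 2 nitrogen, 1 oxygen; one six-membered non-aromatic ring with 2 hetero atoms) in place of a group of 12 heavy atoms (7 carbon, 2 nitrogen, 1 oxygen, 2 sulfur; one six-membered non-aromatic ring with 2 hetero atoms), on a saturated chain carbon bound to a carbonyl carbon. Compound 3 gives 10800 nM, the step being a 29-fold higher number from compound 1 to compound 3 (1.47 log units; beyond the scatter), so the core of compound 3 stands apart from the core of compound 1.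

Compound 4 `COc1ccc(CN(C(=O)CN2CCN(C(=O)OC(C)(C)C)CC2)c2cc(OC)c(OC)c(OC)c2)cc1` has not yet been measured. It differs from compound 3 by tert-butoxy in place of methyl on a carbonyl carbon, which is the same change as between compound 1 and compound 2, made at the same place: on a carbonyl carbon whose other neighbours are an amide-type nitrogen in a ring. Among the compounds with values here, with only one measured pair to rest on, the expectation for compound 4 rests on the step of a 1.5-fold lower number from compound 1 to compound 2 (0.17 log units; within the scatter), which lay within the scatter. The expected step from compound 3 to compound 4 is therefore a 1.4-fold lower number from compound 3 to compound 4 (0.16 log units; within the scatter), of the same small size. Compound 4 is estimated at 7500 nM in this assay, with a likely range from 3000 nM to 20000 nM.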

Compound 4, half-maximal inhibitory concentration: 8170 nM
Compound 4: the middle estimate sits 1.1-fold (0.04 log units) below what was measured; low and high end bracket the measured number.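

Tert-butoxy in place of methyl on a carbonyl carbon gives a 1.3-fold lower number from compound 3 to compound 4 (0.12 log units; within the scatter) in this assay, so on the core of compound 3 this change again stays inside the scatter. Its size holds from the core of compound 1 to the core of compound 3, even though these two cores stand far apart in this assay: the same change on two cores in this assay, a 1.5-fold lower number (0.17 log units; within the scatter) from compound 1 to compound 2 and a 1.3-fold lower number (0.12 log units; within the scatter) from compound 3 to compound 4, 1.1-fold (0.05 log units) apart, within the scatter of two such steps This shows only that acetyl and tert-butoxycarbonyl could not be told apart on either of these two cores in this assay; it does not show that they are interchangeable on other cores or in other assays, and two pairs, both within the scatter, establish no real effect of the change that could be carried over.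

Open, on these data alone, is how a free ring amine, a benzoyl group or a longer acyl chain would read in place of acetyl on either core. Also open is which of the atoms exchanged in the step of a 29-fold higher number from compound 1 to compound 3 (1.47 log units; beyond the scatter) accounts for its size.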